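A Small Change on the Side Ring of Compound 2

This account rests on a few compounds, and the source may have more. Where it says the series, first, only, none or still open, it means among the compounds named here.

Among the compounds with values here, compound 2 `COC(=O)C1=C(C)N=C(C)/C(=C(/O)OC)C1c1ccccc1OCc1c(C)no[n+]1[O-]` holds the lower of the two numbers measured so far in an assay on Cortex for displacement of a labelled ligand from Voltage-dependent L-type calcium channel subunit alpha-1D (Rattus norvegicus) (on this read-out higher numbers stand for weaker inhibition and lower numbers for stronger inhibition), giving 32 nM. Compound 1 `COC(=O)C1=C(C)N=C(C)/C(=C(/O)OC)C1c1cccc(OCc2c(C(N)=O)no[n+]2[O-])c1` differs from it in more than one place and gives 1600 nM in this assay, a far higher number. Compound 3 `COC(=O)C1=C(C)N=C(C)/C(=C(/O)OC)C1c1ccccc1OCc1no[n+]([O-])c1C#N` keeps the core of compound 2 and differs from it by a group of 8 heavy atoms (3 carbon, 3 nitrogen, 2 oxygen; one five-membered aromatic ring with 3 hetero atoms) in place of a group of 7 heavy atoms (3 carbon, 2 nitrogen, 2 oxygen; one five-membered aromatic ring with 3 hetero atoms), on a saturated chain carbon bound to an oxygen on an aromatic ring. Within the data shown here, no step between measured compounds that differ in one place is available to calibrate this change, and the gap to compound 1 cannot be traced to any single difference. The change is expected to shift the number only slightly, probably upward, by a 1.9-fold higher number from compound 2 to compound 3 (0.27 log units; within the scatter), a step that may not exceed the usual scatter. Compound 3 is estimated at 60 nM, within 15 nM to 250 nM.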

Compound 3, inhibition constant: 21 nM
Beside the measured number, compound 3's estimate is 2.9-fold (0.46 log units) above it; the range from low to high includes it.
By their numbers in this assay, from the lowest: compounds 3 and 2 (each within the scatter of the next); then compound 1.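

In this assay, putting the group of 8 heavy atoms with its triple bond outside aromatic rings in place of the group of 7 heavy atoms, on a saturated chain carbon bound to an oxygen on an aromatic ring, gives a 1.5-fold lower number from compound 2 to compound 3 (0.18 log units; within the scatter). This first one-place step shows that the exchange leaves the number at this position indistinguishable from that of compound 2. No measurement is available that bears on this result.

The compounds shown leave open whether a carboxylic acid or an amine on this ring would also stay within the scatter. They also leave open what a longer chain at this place would give.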